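The source may report more compounds than this note shows. Statements on the series, on what has been measured and on what is new or still open speak of the compounds shown alone.

Compound 1 `Nc1cc(Oc2ccc3c(ccn3C(=O)Nc3cccc(C(F)(F)F)c3)c2)ncn1` gives 44% in a functional assay on the whole organism (strain C57BL/6) for inhibition, with Mus musculus as the target, read by microscopy, with a stated time of 6 days, at a dose of 10 mg/kg by the oral route; a higher number here means more inhibition at the dose given (going by the name of the read-out), a lower number less inhibition. Compound 2 `C[C@@H]1NCc2ncnc(Oc3ccc4c(ccn4C(=O)Nc4cccc(C(F)(F)F)c4)c3)c21` gives 41% in this assay. Among the measured compounds shown here, the one step among the measured compounds, a number 3 percentage points lower from compound 1 to compound 2 (within the scatter), exchanged one ring group for another on the oxygen of the shared core, and its size lies within the usual scatter, so the two numbers cannot be told apart; compound 2 stands on a number that is indistinguishable from that of compound 1.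

Compound 3 `C[C@H]1NCc2ncnc(Oc3ccc4c(ccn4C(=O)Nc4cccc(C(F)(F)F)c4)c3)c21` is built from compound 2 with a change of a different kind: the two compounds have the same atoms and bonds and differ only in configuration as drawn: 1 of 1 stereo elements differ; a stereocentre at a saturated ring carbon is drawn S in compound 2 and R in compound 3. For the measured compounds named here, no measured step concerns a change in configuration; the step from compound 1 to compound 2 altered atoms, not their spatial arrangement, and was small. There is therefore no measured guide to how the swap of configuration will read out in this assay, and a step in either direction, or none beyond the scatter, remains possible.

Compound 3 is expected to give about 38% in this assay, within a range from 15% to 60%. That estimate corresponds to an expected step of a number 3 percentage points lower from compound 2 to compound 3 (within the scatter).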

Compound 3, a percentage reported as inhibition, in the whole organism at one dose (the size of the read-out at that dose, not a potency): 0%
Compound 3: the middle estimate sits 38 percentage points above what was measured, outside the stated range (below it).
By their numbers in this assay, from the lowest: compound 3; then compounds 2 and 1 (each within the scatter of the next).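

Changing only the configuration at one saturated ring carbon gives a number 41 percentage points lower from compound 2 to compound 3 (beyond the scatter) in this assay, whereas the earlier step between compounds with different groups on the oxygen, a number 3 percentage points lower from compound 1 to compound 2 (within the scatter), could not be told from the scatter. This large step can be put down to the stereocentre and to nothing else, because one plain fact rules out any other structural change: the fact that compounds 2 and 3 differ only in the configuration as drawn. The step of a number 44 percentage points lower from compound 1 to compound 3 (beyond the scatter) adds that exchanging the group on the oxygen for this ring group can leave the reading unchanged or take it down sharply, depending on how that one ring carbon is drawn, so the ring group by itself does not set the result.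

The compounds shown do not tell whether the difference between the two configurations arises at the target or from how much of each compound reaches it in the whole organism. They also leave open what happens at this saturated ring carbon when an ethyl group or a hydroxyl group is carried there in either configuration, and whether the same sharp dependence on configuration would then appear.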